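Swapping the benzyl group on compound 3

The compounds below may be only part of what the source reports. "The series", "measured", "known", "first", "only" and "open" are said of these compounds alone.

Measured in a functional assay on MDA-MB-231 cells (Homo sapiens) for inhibition, read by CCK-8 assay, with a stated time of 48 h; a higher number here means a weaker inhibitor of growth, a lower number a stronger inhibitor of growth:
- compound 1 `Cc1ccccc1Nc1nc(NCc2ccco2)ncc1Cl`: > 100000 nM (a limit, not a number)
- compound 2 `CCN1CCN(c2ccc(Nc3ncc(Cl)c(Nc4ccccc4C)n3)nc2)CC1`: > 100000 nM (a limit, not a number)
- compound 3 `CN1CCN(c2ccc(Nc3ncc(Cl)c(NCc4ccc(C(F)(F)F)cc4)n3)nc2)CC1`: 19100 nM

Only compound 3 has an actual number, 19100 nM, so it is the sole anchor on the scale. The other two results are limits, so they give no exact figure.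

Compound 4 `COc1ccccc1CNc1nc(Nc2ccc(N3CCN(C)CC3)cn2)ncc1Cl` differs from compound 3 in one group: 2-methoxyphenyl in place of 4-(trifluoromethyl)phenyl on a saturated chain carbon bound to a nitrogen on an aromatic ring. Among the compounds with values here, no measured pair shows this kind of swap. The data lean toward weak inhibition, given (the limit of > 100000 nM in this assay, at which 2 of the 3 values shown sit). A moderate move toward weaker inhibition in this assay is therefore expected, and the expected size is a 2.1-fold higher number from compound 3 to compound 4 (0.32 log units; beyond the scatter). Compound 4 is estimated at 40000 nM, with an expected range of 13000 nM to 100000 nM.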

Compound 4, concentration for 50% growth inhibition: 29300 nM
For compound 4 the middle estimate is 1.4-fold (0.14 log units) above the measured one; low and high end bracket the measured number.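

In this assay, 2-methoxyphenyl in place of 4-(trifluoromethyl)phenyl gives a 1.5-fold higher number from compound 3 to compound 4 (0.19 log units; within the scatter), so this is no real shift. This position therefore accepts two quite different ring groups, one carrying a hydrogen-bond acceptor that the other lacks, with the same weak reading. Nothing measured here explains why the two groups read alike.

As far as these compounds go, whether an amine or a carboxylic acid on this ring would move the number stays open. So does the reading of 4-methoxyphenyl, which would separate the effect of the group from that of its place on the ring.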